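Moving the methoxy group on the benzylamine side chain

The source may report more compounds than this note shows. Statements on the series, on what has been measured and on what is new or still open speak of the compounds shown alone.

Two compounds share a core in which a sulfonamide bearing two trifluoromethyl groups is joined through a three-carbon chain to a benzylamine. Compound 1 `COc1ccc(CNCCCNS(=O)(=O)c2cc(C(F)(F)F)cc(C(F)(F)F)c2)cc1` carries a methoxy group on its benzyl ring, and compound 2 `O=S(=O)(NCCCNCc1ccc(Cl)cc1)c1cc(C(F)(F)F)cc(C(F)(F)F)c1` carries a chlorine in the same place. In a functional assay on HT-29 cells (Homo sapiens) for inhibition, read by MTT assay, with a stated time of 72 h (a higher number here means a weaker inhibitor of growth, a lower number a stronger inhibitor of growth), compound 1 gives 2900 nM and compound 2 gives 2800 nM; the step of a 1.0-fold lower number from compound 1 to compound 2 (0.02 log units; within the scatter) shows that swapping these two groups changes little, and the two numbers stand within the scatter of each other. Compound 3 `COc1ccccc1CNCCCNS(=O)(=O)c1cc(C(F)(F)F)cc(C(F)(F)F)c1` is not yet measured; it differs from compound 2 by 2-methoxyphenyl in place of 4-chlorophenyl on a saturated chain carbon bound to an amine nitrogen. Going by the values given here, no measured step tells what moving a group to this position does, and the only step at hand, from compound 1 to compound 2, was within the scatter. The expected step of a 1.1-fold higher number from compound 2 to compound 3 (0.03 log units; within the scatter) is therefore small, and compound 3 is estimated at 3000 nM, with a range from 1200 nM to 7500 nM.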

Compound 3, concentration for 50% growth inhibition: 12000 nM
Beside the measured number, compound 3's estimate is 4.0-fold (0.60 log units) below it; the measured number lies above the stated range.
By their numbers in this assay, from the lowest: compounds 2 and 1 (each within the scatter of the next); then compound 3.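

Compound 3 shows that the place of the methoxy group on the ring matters in this assay: 2-methoxyphenyl in place of 4-methoxyphenyl gives a 4.1-fold higher number from compound 1 to compound 3 (0.62 log units; beyond the scatter), a change that the swap of methoxy for chloro had given no sign of. The step from 4-chlorophenyl to 2-methoxyphenyl is of similar size, a 4.3-fold higher number from compound 2 to compound 3 (0.63 log units; beyond the scatter), so compound 3 is a weaker inhibitor of growth than either earlier compound. Nothing measured here explains why this change weakens growth inhibition.

From the compounds shown here alone, it remains open whether the loss belongs to the methoxy group itself or would follow any other group placed where it stands in compound 3. A plain phenyl ring with no added group would give a reference point for judging all three compounds.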